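Compound 3: Methoxy to Hydroxy on a Pyrazolyl-Urea Scaffold

The source may hold more compounds than are shown below. What is called first, only, known or untested is meant among the compounds shown, and "the series" means these compounds.

Of the compounds shown here, two have been measured in a functional assay on K562 cells (Homo sapiens) for inhibition, read by sulforhodamine B assay, with a stated time of 48 h, tested at 1 uM; on this read-out lower numbers stand for a stronger effect and higher numbers for a weaker effect at the one concentration tested. Compound 1 `COc1cc(Cl)cc(-c2nn(-c3cccc(NC(=O)Nc4ccc(Cl)c(C(F)(F)F)c4)c3)cc2-c2ccncc2)c1` gives 35%. Compound 2 `COc1cc(Cl)cc(-c2nn(-c3cccc(NC(=O)c4cccc(C(F)(F)F)c4)c3)cc2-c2ccncc2)c1` gives 90%. On these two numbers compound 1 stands as the lower of the pair, the stronger effect. Among the measured compounds shown here, the only measured step, a number 55 percentage points higher from compound 1 to compound 2 (beyond the scatter), alters the group on the carbonyl carbon, a part of the molecule far from the one changed here.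

Compound 3 `O=C(Nc1cccc(-n2cc(-c3ccncc3)c(-c3cc(O)cc(Cl)c3)n2)c1)Nc1ccc(Cl)c(C(F)(F)F)c1` differs from compound 1 by hydrogen in place of methyl on an oxygen on an aromatic ring. For the measured compounds named here, no measured pair shows this particular change, so the single recorded step offers no direct guide; it shows only that a remote part of the molecule can matter greatly. With nothing pointing either way, the step of a number 5 percentage points higher from compound 1 to compound 3 (within the scatter) is expected to stay within the scatter. Compound 3 is therefore estimated at 40%, with a range from 15% to 70%.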

Compound 3, a percentage reported as activity, at one concentration (the size of the read-out at that concentration, not a potency): 55%
Compound 3: the middle estimate sits 15 percentage points below what was measured; low and high end bracket the measured number.
By their numbers in this assay, from the lowest: compound 1; then compound 3; then compound 2.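

Replacing methoxy with hydroxy on the 3-chloro-5-methoxyphenyl group is not a neutral swap in this assay: it gives a number 20 percentage points higher from compound 1 to compound 3 (beyond the scatter), a modest weakening of the effect. Among the compounds shown here, the earlier step changed only the group on the carbonyl carbon, so this is the first result to show that the read-out also responds to a change at this oxygen on the aromatic ring, even when only a methyl gives way to hydrogen. No measurement on hand explains this shift.

Still open, on these data alone, is whether the weakening follows the loss of the methyl or the presence of the hydroxy, a question that an ethoxy group or an amine at this place could help to answer. Also open, as far as these compounds go, is whether the same swap would shift compound 2 by a similar amount.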